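Methoxy in Place of 4-Fluorophenyl

The source may report more compounds than this note shows. Statements on the series, on what has been measured and on what is new or still open speak of the compounds shown alone.

In an ADME assay on HCT-116 cells (Homo sapiens) for cytotoxicity, read by CellTiter-Glo, with a stated time of 72 h (on this read-out lower numbers stand for stronger inhibition and higher numbers for weaker inhibition), compound 3 `CC1CCN(C2CCN(S(=O)(=O)c3cccc(-c4ccc(F)cc4)c3)CC2)CC1` reads > 5000 nM, which is a limit of the assay and not a number. Compound 2 `CC1CCN(C2CCN(S(=O)(=O)c3cccc(Cl)c3)CC2)CC1` reads > 5000 nM, which is also a limit. Compound 1 `CC1CCN(C2CCN(S(=O)(=O)c3ccc(Cl)nc3)CC2)CC1` reads > 10000 nM, again a limit. Among the compounds with values here, no compound measured so far therefore has a number to start from.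

Compound 4 `COc1cccc(S(=O)(=O)N2CCC(N3CCC(C)CC3)CC2)c1` changes compound 3 at one place, methoxy in place of 4-fluorophenyl on an aromatic carbon.

Within the data shown here, two measured steps bear on this change. The closer one is a step that the two limits leave unreadable from compound 2 to compound 3, made at the same aromatic carbon, and the other is a step that the two limits leave unreadable from compound 1 to compound 2. Neither has a readable size, so neither points to a step of any particular size or direction. The step expected is therefore none beyond the scatter, estimated as a step that the limit leaves unreadable from compound 3 to compound 4. Compound 4 is expected to be reported as a limit as well. The estimated value for compound 4 is 10000 nM, with an expected range of 5000 nM to 20000 nM.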

Compound 4, half-maximal inhibitory concentration: > 5000 nM
Compound 4: no number, only a limit; the forecaster's own chance of this, stated with the estimate: 90%; the middle value does not contradict the limit.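

In this assay compound 4 gives > 5000 nM, which is a limit and not a number. Its steps from compound 1, compound 2 and compound 3 cannot be read. The compounds shown leave open how strongly any of them inhibits, and whether any of these changes shifts the read-out at all.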